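A few compounds are considered here, and "the series" means these few. Any claim that something is new, unique, unknown or untested is made for them only; others in the source may bear on it.

Compound 1 `N#Cc1ccc(Nc2nccc(OCc3ccccc3Cl)n2)cc1`: 146000 nM
Compound 2 `N#Cc1ccc(Nc2nccc(OCc3ccccc3C#N)n2)cc1`: 113000 nM

In an ADME assay on MT4 cells (Homo sapiens) for cytotoxicity, read by MTT assay, with a stated time of 5 days (a higher number here means that more compound is tolerated, a lower number that less compound is tolerated), compound 1 gives the larger of the two numbers, though the gap to compound 2 is within the scatter, a 1.3-fold lower number from compound 1 to compound 2 (0.11 log units; within the scatter). Compound 3 `N#Cc1ccc(COc2ccnc(Nc3ccc(C#N)cc3)n2)cc1` differs from compound 1 by 4-cyanophenyl in place of 2-chlorophenyl on a saturated chain carbon bound to an oxygen on an aromatic ring. For the measured compounds named here, the one measured step, cyano in place of chloro on an aromatic carbon, bears on this only in part and itself stayed within the scatter, so no step beyond the scatter is expected in this assay, a 1.1-fold lower number from compound 1 to compound 3 (0.05 log units; within the scatter). Compound 3 is therefore estimated at 130000 nM, with a range from 60000 nM to 260000 nM.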

Compound 3, half-maximal cytotoxic concentration: 209000 nM
Compound 3: middle estimate off by 1.6-fold (0.21 log units), on the low side; the range from low to high includes it.
By their numbers in this assay, from the lowest: compounds 2, 1 and 3 (each within the scatter of the next).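

Compound 3, with 4-cyanophenyl on a saturated chain carbon bound to an oxygen on an aromatic ring, stays within the scatter of both earlier compounds in this assay (a 1.4-fold higher number from compound 1 to compound 3 (0.16 log units; within the scatter)) (a 1.8-fold higher number from compound 2 to compound 3 (0.27 log units; within the scatter)). The 4-cyanophenyl group thus joins 2-chlorophenyl and 2-cyanophenyl at this place, with no step beyond the scatter among the three compounds. Nothing available here accounts for these numbers. From the compounds shown here alone, whether an amine or a carboxylic acid on the ring at this place, or a longer chain, would give a step beyond the scatter remains open.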